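The source may hold more compounds than are shown below. What is called first, only, known or untested is meant among the compounds shown, and "the series" means these compounds.

Measured values in an ADME assay on microsomes from liver (Homo sapiens) for metabolic stability, with a stated time of 10 min (on this read-out lower numbers stand for a less stable compound and higher numbers for a more stable compound), so far
- compound 1 `COC[C@]1(C(=O)N2CC[C@](c3ccc(C(F)(C(F)(F)F)C(F)(F)F)cc3)(S(=O)(=O)c3ccc(F)cc3)C2)CC[C@H](C(=O)O)CC1` gives 100%
- compound 2 `C[C@]1(C(=O)N2CC[C@](c3ccc(C(F)(C(F)(F)F)C(F)(F)F)cc3)(S(=O)(=O)c3ccc(F)cc3)C2)CC[C@@H](C(=O)O)CC1` gives 85%
- compound 3 `O=C([C@H]1CC[C@H](c2nnn[nH]2)CC1)N1CC[C@](c2ccc(C(F)(C(F)(F)F)C(F)(F)F)cc2)(S(=O)(=O)c2ccc(F)cc2)C1` gives 100%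

Compound 3 stands level with compound 1 at the digits shown, and together they hold the top of the three numbers. Compound 2 is the only one that sits apart.

The next compound is compound 4 `NC(=O)[C@H]1CC[C@H](C(=O)N2CC[C@](c3ccc(C(F)(C(F)(F)F)C(F)(F)F)cc3)(S(=O)(=O)c3ccc(F)cc3)C2)CC1`, which keeps the shared core and changes one group (carbamoyl in place of 1H-tetrazol-5-yl on a saturated ring carbon). Carbamoyl replaces 1H-tetrazol-5-yl on a saturated ring carbon, three ring bonds from the ring atom that bears a large group.

Among the compounds with values here, no measured step makes this exact exchange, so the evidence is indirect. The closest comparison also changes the group at that ring position and shows no movement (no change at the digits printed from compound 1 to compound 3 (within the scatter)). The other two steps are modest (a number 15 percentage points lower from compound 1 to compound 2 (beyond the scatter) and a number 15 percentage points higher from compound 2 to compound 3 (beyond the scatter)), and they set the largest movement seen in this small set. Compound 3 already sits at the top of the read-out (100%), so any movement can only be downward.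

The step expected for compound 4 is small and downward, with nothing expected beyond the scatter (a number 8 percentage points lower from compound 3 to compound 4 (within the scatter)). Compound 4 is estimated at 92% (expected range 78% to 100%).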

Compound 4, percent of the compound remaining: 100%
For compound 4 the middle estimate is 8 percentage points below the measured one; measured number inside the range.
By their numbers in this assay, from the lowest: compound 2; then compounds 1, 3 and 4 (each within the scatter of the next).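

In this assay the saturated ring carbon three ring bonds from the ring atom that bears a large group accepts carbamoyl in place of 1H-tetrazol-5-yl, with no change at the digits printed from compound 3 to compound 4 (within the scatter), so a five-membered aromatic ring with 4 hetero atoms is not needed there to keep this read-out. Within the data shown here, the 4-carbamoylcyclohexyl group also reads the same as 4-carboxy-1-(methoxymethyl)cyclohexyl, with no change at the digits printed from compound 1 to compound 4 (within the scatter), while in place of 4-carboxy-1-methylcyclohexyl it gives a number 15 percentage points higher from compound 2 to compound 4 (beyond the scatter), which leaves compound 2 as the only compound of the four that sits apart. No measurement on hand bears on why these different groups read alike.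

As far as these compounds go, compound 1, compound 3 and compound 4 all stand at the top of the read-out at this single stated time, so this assay does not tell them apart, and it stays open whether an amine, a nitrile or a longer chain on the same ring carbon would stay level with them. From the compounds shown here alone, it also stays open whether a methyl on the ring carbon bearing the carbonyl would lower the number with carbamoyl on the ring, as it does in the step to compound 2.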